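This account rests on a few compounds, and the source may have more. Where it says the series, first, only, none or still open, it means among the compounds named here.

Measured so far:
- compound 1, `COc1ccc(Oc2ccc3c(NCCCNCc4cc(F)ccc4OC)ccnc3c2)cc1`: 7000 nM
- compound 2, `COc1ccc(F)cc1CNCCCNc1ccnc2cc(Oc3cccc(N(C)C)c3)ccc12`: 3300 nM
- compound 3, `COc1ccc(Oc2ccc3c(NCCCNCc4cccc(OC)c4O)ccnc3c2)cc1`: 5500 nM

All three were read in an ADME assay on HepG2 cells (Homo sapiens) for cytotoxicity, read by luminescence, CellTiter-Glo and ATP content, with a stated time of 72 h; a higher number here means that more compound is needed for the effect, a lower number that less compound is needed. Compound 4, `COc1cccc(CNCCCNc2ccnc3cc(Oc4cccc(N(C)C)c4)ccc23)c1O`, has not yet been measured there.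

The change from compound 3 to compound 4 is 3-(dimethylamino)phenyl in place of 4-methoxyphenyl on an oxygen on an aromatic ring. The same change has been made once before, from compound 1 to compound 2, where it is 3-(dimethylamino)phenyl in place of 4-methoxyphenyl on an oxygen on an aromatic ring, and there it gave a 2.1-fold lower number from compound 1 to compound 2 (0.33 log units; beyond the scatter). The two "place" descriptions agree word for word, so this is the same change, not merely the same kind.

The cores of the two pairs differ: compound 3 is reached from compound 1 by 2-hydroxy-3-methoxyphenyl in place of 5-fluoro-2-methoxyphenyl on a saturated chain carbon bound to an amine nitrogen, a step of a 1.3-fold lower number from compound 1 to compound 3 (0.10 log units; within the scatter), so compound 1 and compound 3 sit within the scatter of each other in this assay.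

For the measured compounds named here, for compound 4 in this assay a step of about a 2.1-fold lower number from compound 3 to compound 4 (0.33 log units; beyond the scatter) from compound 3 is expected, resting on the single earlier instance, a 2.1-fold lower number from compound 1 to compound 2 (0.33 log units; beyond the scatter), and on compound 3 starting near compound 1. Compound 4 is therefore estimated at 2600 nM, with a range from 1300 nM to 5500 nM.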

Compound 4, half-maximal effective concentration: 7300 nM
Estimate against measurement, compound 4: 2.8-fold (0.45 log units) below, and the stated range ends below it.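

In this assay the exchange of 4-methoxyphenyl for 3-(dimethylamino)phenyl gives a 1.3-fold higher number from compound 3 to compound 4 (0.12 log units; within the scatter), so the earlier step does not carry over in size to the core of compound 3: the same change on two cores in this assay, a 2.1-fold lower number (0.33 log units; beyond the scatter) from compound 1 to compound 2 and a 1.3-fold higher number (0.12 log units; within the scatter) from compound 3 to compound 4, 2.8-fold (0.45 log units) apart, beyond the scatter of two such steps

Read along the other edge, the exchange of 5-fluoro-2-methoxyphenyl for 2-hydroxy-3-methoxyphenyl gives a 2.2-fold higher number from compound 2 to compound 4 (0.34 log units; beyond the scatter), so the outcome of each exchange depends on the group at the other place: the same change on two cores in this assay, a 1.3-fold lower number (0.10 log units; within the scatter) from compound 1 to compound 3 and a 2.2-fold higher number (0.34 log units; beyond the scatter) from compound 2 to compound 4, 2.8-fold (0.45 log units) apart, beyond the scatter of two such steps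

These four compounds form a single set, so the two comparisons are one observation seen from two sides; they show that the two exchanges do not simply add here, but not which group is responsible, why it happens or how the exchange would behave on any further core.

Still open, going by these compounds, is whether an unsubstituted phenyl on the same oxygen would follow the compound 1 to compound 2 step or the compound 3 to compound 4 step. Also open, on these data alone, is whether a longer chain linking the two amine nitrogens would leave this dependence in place.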